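Methoxy replacing methyl on the series core

The compounds below may be only part of what the source reports. "The series", "measured", "known", "first", "only" and "open" are said of these compounds alone.

Three members of the series have been run in a functional assay on HepG2 cells (Homo sapiens) for cytotoxicity, read by MTT assay, with a stated time of 48 h; a lower number here means a stronger inhibitor, a higher number a weaker inhibitor. Compound 1, `Cc1ccc2[nH]c(=O)c(-c3nc4cc([N+](=O)[O-])ccc4[nH]3)cc2c1`, reaches only the limit of the assay, giving > 100000 nM. Compound 2, `Cc1ccc2[nH]c(=O)c(-c3nc4cc(Br)ccc4[nH]3)cc2c1`, likewise gives a limit rather than a number, > 100000 nM. Compound 3, `Cc1ccc2[nH]c(=O)c(-c3nc4cc(F)ccc4[nH]3)cc2c1`, also stops at a limit, > 100000 nM. Because all three sit at the limit of > 100000 nM in this assay, at which 3 of the 3 values shown sit, the steps among them carry no readable size: a step that the two limits leave unreadable from compound 1 to compound 2, a step that the two limits leave unreadable from compound 1 to compound 3 and a step that the two limits leave unreadable from compound 2 to compound 3. Compound 3 therefore stands only at a limit, with no rank against its two neighbours.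

Compound 4, `COc1ccc2[nH]c(=O)c(-c3nc4cc(F)ccc4[nH]3)cc2c1`, differs from compound 3 in one place: methoxy in place of methyl on an aromatic carbon.

For the measured compounds named here, none of the measured steps bears on this change; they all concern the substituent on the other ring and none can be read in size. The exchange of a methyl for a methoxy gives no ground, on these numbers, for expecting a step in this assay beyond the scatter, and compound 4 is expected to remain at the limit as well. The estimated step from compound 3 to compound 4 is a number no higher from compound 3 to compound 4 (the limit leaves the size open). For compound 4 the value is estimated at 100000 nM, within 50000 nM to 300000 nM.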

Compound 4, half-maximal inhibitory concentration: > 100000 nM
Compound 4 was reported as a limit (the forecaster's own chance of this, stated with the estimate: 85%); the middle value sits exactly at the limit.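

In this assay compound 4 gives > 100000 nM, which is a limit, so the exchange of methyl for methoxy between compound 3 and compound 4 yields no readable step: the limit of > 100000 nM in this assay, at which 4 of the 4 values shown sit.

The compounds shown leave open whether either group, or any substituent on the other ring, alters the read-out in this assay once a value falls within measurable range.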